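From compound 2 to compound 4: cyclopentylmethoxy gives way to hydrogen

A few compounds are considered here, and "the series" means these few. Any claim that something is new, unique, unknown or untested is made for them only; others in the source may bear on it.

compound 1 `O=C1N=C(O)S/C1=C\c1ccc(OCC2CCCCC2)cc1` gives 3.66
compound 2 `O=C1NC(=O)C(Cc2ccc(OCC3CCCC3)cc2)S1` gives 3.38
compound 3 `O=C1NC(=O)/C(=C/c2ccc(OCC3CCC3)cc2)S1` gives 2.54

In a physicochemical assay for lipophilicity (on this read-out lower numbers stand for lower lipophilicity and higher numbers for higher lipophilicity), compound 2 lies within the scatter of compound 1 and beyond the scatter above compound 3. Still unmeasured, compound 4 `O=C1NC(=O)C(Cc2ccccc2)S1` differs from compound 2 in one place (hydrogen in place of cyclopentylmethoxy on an aromatic carbon), with hydrogen in place of cyclopentylmethoxy on an aromatic carbon. Going by the values given here, no measured pair shows this change, so the expectation rests on the structures alone. A clear fall in this assay is expected, well beyond the scatter, and the estimated step is a number 1.58 log units lower from compound 2 to compound 4 (beyond the scatter) in size. For compound 4 the estimate is 1.8 with an expected range from 1.3 to 2.3 for the coming measurement.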

Compound 4, partition coefficient: 1.99
Estimate against measurement, compound 4: 0.19 log units below, within the range that was stated.
By their numbers in this assay, from the lowest: compound 4; then compound 3; then compounds 2 and 1 (each within the scatter of the next).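

In this assay, going by these compounds alone, hydrogen in place of cyclopentylmethoxy on an aromatic carbon gives a number 1.39 log units lower from compound 2 to compound 4 (beyond the scatter), the first change here that can be read alone, as no earlier pair of compounds differed in one place. The value thus depends strongly on what occupies this position. Nothing available explains the size of this step. As far as these compounds go, it remains open where a methoxy group, an amine or a carboxylic acid at this position would fall relative to hydrogen and cyclopentylmethoxy. Also open, from the compounds shown here alone, is whether the same change would give a step of similar size on the core of compound 3.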